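A few compounds are considered here, and "the series" means these few. Any claim that something is new, unique, unknown or untested is made for them only; others in the source may bear on it.

Within the data shown here, compound 2 `COc1cc2cc(Oc3ccc(NC(=O)Nc4ccc(Cl)c(C(F)(F)F)c4)cc3)c(C)nc2cc1OC` stands lowest of the two numbers measured so far in a functional assay on SF-268 cells (Homo sapiens) for inhibition, read by sulforhodamine B assay, with a stated time of 48 h (a higher number here means a weaker inhibitor of growth, a lower number a stronger inhibitor of growth), at 1550 nM. Compound 1 `COc1cc2cc(Oc3ccc(NC(=O)Nc4cccc(C(F)(F)F)c4)cc3)c(C)nc2cc1OC` gives 2570 nM in this assay. Among the measured compounds shown here, the only step available, a 1.7-fold lower number from compound 1 to compound 2 (0.22 log units; within the scatter), concerns a different position and is within the scatter, so it gives no guide to the present change. Compound 3 `COc1cc2cc(Oc3ccc(NC(=O)Nc4ccc(Cl)c(Cl)c4)cc3)c(C)nc2cc1OC` differs from compound 2 by chloro in place of trifluoromethyl on an aromatic carbon. For the measured compounds named here, no measured pair exchanges these two groups. The step of a 1.3-fold higher number from compound 2 to compound 3 (0.11 log units; within the scatter) is therefore expected to stay within the scatter. Compound 3 is estimated at 2000 nM, with a range of 800 nM to 5000 nM.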

Compound 3, concentration for 50% growth inhibition: 8230 nM
Estimate against measurement, compound 3: 4.1-fold (0.61 log units) below; measured number outside the range, above it.
By their numbers in this assay, from the lowest: compounds 2 and 1 (each within the scatter of the next); then compound 3.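

In this assay, this position is sensitive to the group it carries, and chloro does not stand in for trifluoromethyl here: a 5.3-fold higher number from compound 2 to compound 3 (0.73 log units; beyond the scatter). Among these compounds, the 3,4-dichlorophenyl group also separates from the 3-(trifluoromethyl)phenyl group, with a 3.2-fold higher number from compound 1 to compound 3 (0.51 log units; beyond the scatter), whereas the only earlier step stayed within the scatter. Nothing available accounts for this difference. Open, as far as these compounds go, is how other groups at this position, such as methyl, methoxy or an amine, would compare with trifluoromethyl and chloro.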